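A few compounds are considered here, and "the series" means these few. Any claim that something is new, unique, unknown or untested is made for them only; others in the source may bear on it.

In a physicochemical assay for lipophilicity, using the shake flask method, at pH 7.4 (on this read-out higher numbers stand for higher lipophilicity and lower numbers for lower lipophilicity), compound 1 `Cc1cc2c(N[C@H]3CC[C@H](N(C)C)CC3)ncnc2s1` gives 0.6 and compound 2 `CN(C)[C@H]1CC[C@H](Nc2ncnc3[nH]cc(C4CCCC4)c23)CC1` gives 1.7 while compound 3 `CC(=O)N1CCN([C@H]2CC[C@H](Nc3ncnc4[nH]cc(C5CCOCC5)c34)CC2)CC1` gives 1.3 and so stands second highest of the three, with both of its gaps beyond the usual scatter. Compound 4 `COC(=O)N1CCN([C@H]2CC[C@H](Nc3ncnc4[nH]cc(C5CCOCC5)c34)CC2)CC1` has methoxy in place of methyl on a carbonyl carbon and thus turns acetyl to methoxycarbonyl while the rest of compound 3 stays the same. Going by the values given here, no measured pair here shows this change on its own, so the data offer no direct guide. A modest rise is expected, with the estimated change a number 0.50 log units higher from compound 3 to compound 4 (beyond the scatter) lying slightly beyond the scatter. Compound 4 is therefore estimated at 1.8 with an expected range from 1.4 to 2.2 in this measurement.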

Compound 4, distribution coefficient: 2
Compound 4: middle estimate off by 0.20 log units, on the low side; measured number inside the range.
By their numbers in this assay, from the lowest: compound 1; then compound 3; then compounds 2 and 4 (each within the scatter of the next).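

In this assay, going by these compounds alone, the change of acetyl to methoxycarbonyl, methoxy in place of methyl on a carbonyl carbon, gives a number 0.70 log units higher from compound 3 to compound 4 (beyond the scatter) and is the first direct reading of this swap. It shows that this carbonyl carbon is a place where a small edit, with the rest of the molecule unchanged, can shift the number clearly. No measurement shown here accounts for the rise. Going by these compounds, whether an amine or a longer chain such as ethoxy on the same carbonyl carbon would shift it further stays open. So does whether methoxy has the same effect on a different core.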